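From a Hydroxybutynyl Chain to a Two-Ring Group

A few compounds are considered here, and "the series" means these few. Any claim that something is new, unique, unknown or untested is made for them only; others in the source may bear on it.

Compound 2 `Nc1ccc(S(=O)(=O)N2CCN(c3ncc(C(O)(C(F)(F)F)C(F)(F)F)cc3C#CCCO)CC2)cn1` carries a 4-hydroxybut-1-yn-1-yl group on the shared core. In an ADME assay (liver) for metabolic stability, with Liver microsome (Homo sapiens) as the target, using microsomes and NADPH, with a stated time of 30 min, tested at 1 uM (on this read-out higher numbers stand for fast clearance and lower numbers for slow clearance), compound 2 gives < 14 mL.min-1.g-1, which is a limit of the assay rather than a number. Compound 1 `Nc1ccc(S(=O)(=O)N2CCN(c3ncc(C(O)(C(F)(F)F)C(F)(F)F)cc3C#CC3CC3)CC2)cn1` bears a cyclopropyl on the triple-bonded carbon instead, and in this assay compound 1 gives < 14 mL.min-1.g-1, again only a limit. The step that the two limits leave unreadable from compound 1 to compound 2 therefore cannot be read, because of the limit of < 14 mL.min-1.g-1 in this assay, at which 2 of the 2 values shown sit. Compound 3 `Nc1ccc(S(=O)(=O)N2CCN(c3ncc(C(O)(C(F)(F)F)C(F)(F)F)cc3-c3ccc4c(c3)CC(=O)N4)CC2)cn1` is not yet measured; it differs from compound 2 as follows: a group of 10 heavy atoms (8 carbon, 1 nitrogen, 1 oxygen; one five-membered non-aromatic ring with 1 hetero atom, one six-membered aromatic ring of carbon only) in place of a group of 5 heavy atoms (4 carbon, 1 oxygen; no ring), on an aromatic carbon. Among the measured compounds shown here, no measured step bears directly on this change, and both known values are limits, so no direction can be taken from them. Compound 3 is nonetheless expected to sit somewhat higher, an estimated step of an at least 1.4-fold higher number from compound 2 to compound 3 (0.15 log units; that floor lies within the scatter). In this assay the estimate for compound 3 is 20 mL.min-1.g-1, with a range from 8 mL.min-1.g-1 to 50 mL.min-1.g-1.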

Compound 3, intrinsic clearance in microsomes: < 14 mL.min-1.g-1
Compound 3 gave a limit, no number (the forecaster's own chance of this, stated with the estimate: 40%); middle value at least 1.4-fold (0.15 log units) away from the limit.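

Compound 3 also gives only a limit in this assay, so no step among compound 1, compound 2 and compound 3 can be read: the limit of < 14 mL.min-1.g-1 in this assay, at which 3 of the 3 values shown sit.

The compounds shown leave open how far their true clearances lie from that limit, and whether the three groups differ at all.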